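Replacing fluorine with a basic amine chain on a weak sulfone

The source may report more compounds than this note shows. Statements on the series, on what has been measured and on what is new or still open speak of the compounds shown alone.

Compound 1 `O=[N+]([O-])c1cccc(S(=O)(=O)c2nc(-c3cnn4ccc(Br)cc34)cs2)c1` gives 5450 nM in an assay on isolated protein for inhibition of phosphatidylinositol 4,5-bisphosphate 3-kinase catalytic subunit beta isoform (Homo sapiens); on this read-out lower numbers stand for stronger inhibition and higher numbers for weaker inhibition.
Compound 2 `N#Cc1cc(S(=O)(=O)c2nc(-c3cnn4ccc(Br)cc34)cs2)ccc1F` gives > 1000 nM in this assay, which is a limit of the assay and not a number.

Among the measured compounds shown here, compound 2 therefore stands only at a limit in this assay, and the sole measured step, a step that the limit leaves unreadable from compound 1 to compound 2, has no readable size because the limit of > 1000 nM in this assay, at which 1 of the 2 values shown sits, hides where compound 2 actually lies. Compound 3 `CN(C)CCN(C)c1ccc(S(=O)(=O)c2nc(-c3cnn4ccc(Br)cc34)cs2)cc1C#N` differs from compound 2 in one place: (2-(dimethylamino)ethyl)(methyl)amino in place of fluoro on an aromatic carbon. For the measured compounds named here, no measured step involves this change, and both measured compounds are weak inhibitors, so the expectation for compound 3 rests only on compound 2 sitting at its limit and on compound 1 at its value. Compound 3 is thus expected to remain a weak inhibitor, estimated at 3000 nM with a range from 500 nM to 20000 nM. The step that the limit leaves unreadable from compound 2 to compound 3 this estimate implies is an expectation with no measured support for its direction.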

Compound 3, half-maximal inhibitory concentration: > 1000 nM
Compound 3 was reported as a limit; the forecaster's own chance of this, stated with the estimate: 50%; the middle value does not contradict the limit.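

In this assay compound 3 gives > 1000 nM, which is a limit of the assay and not a number. Compound 2 also stands at a limit, so no step can be read between compound 2 and compound 3: the limit of > 1000 nM in this assay, at which 2 of the 3 values shown sit.

The compounds shown leave open where compound 2 and compound 3 actually lie, and whether (2-(dimethylamino)ethyl)(methyl)amino in place of fluoro strengthens or weakens inhibition.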